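The compounds below may be only part of what the source reports. "The series", "measured", "known", "first", "only" and "open" are said of these compounds alone.

Measured compounds in a functional assay on PC-3 cells (Homo sapiens) for antiproliferative activity, read by MTT assay, with a stated time of 48 h; a lower number here means a stronger inhibitor, a higher number a weaker inhibitor:
- compound 1 `COc1ccc(CN(C(=O)CSc2nc3ccccc3s2)c2cc(OC)c(OC)c(OC)c2)cc1N=[N+]=[N-]`: 14400 nM
- compound 2 `COc1cc(N(Cc2ccccc2)C(=O)CSc2nc3ccccc3s2)cc(OC)c1OC`: 54100 nM
- compound 3 `COc1cc(N(Cc2ccc(Cl)cc2)C(=O)CSc2nc3ccccc3s2)cc(OC)c1OC`: for compound 3 the assay reports only a limit, > 80000 nM, and no number.

Compound 1 holds the lowest of the two numbers shown; its nearest neighbour is compound 2, reached by a 3.8-fold higher number from compound 1 to compound 2 (0.57 log units; beyond the scatter). Compound 3 sits at the limit (the limit of > 80000 nM in this assay, at which 1 of the 3 values shown sits).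

Compound 4 `COc1cc(N(Cc2ccc(F)cc2)C(=O)CSc2nc3ccccc3s2)cc(OC)c1OC` has not been measured. It differs from compound 1 by 4-fluorophenyl in place of 3-azido-4-methoxyphenyl on a saturated chain carbon bound to an amide-type nitrogen. Going by the values given here, two measured steps bear on this: a 3.8-fold higher number from compound 1 to compound 2 (0.57 log units; beyond the scatter) and an at least 5.5-fold higher number from compound 1 to compound 3 (0.74 log units; beyond the scatter), both replacing the 3-azido-4-methoxyphenyl group with a plain or substituted phenyl and both moving the number upward beyond the scatter. The step of an at least 1.4-fold higher number from compound 2 to compound 3 (0.16 log units; that floor lies within the scatter), chloro in place of hydrogen on an aromatic carbon, has a floor within the scatter, so whether a 4-fluorophenyl lands nearer compound 2 or compound 3 cannot be told from these data.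

Compound 4 is therefore expected to give a clearly higher number than compound 1 in this assay, with the step of a 4.2-fold higher number from compound 1 to compound 4 (0.62 log units; beyond the scatter). The estimate for compound 4 is 60000 nM, within a range of 20000 nM to 160000 nM, with a real chance that only a limit is reported.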

Compound 4, half-maximal inhibitory concentration: 50800 nM
For compound 4 the middle estimate is 1.2-fold (0.07 log units) above the measured one, and the stated range covers the measured number.
By their numbers in this assay, from the lowest: compound 1; then compounds 4 and 2 (each within the scatter of the next). At a limit, above all of these: compound 3.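

In this assay, the 4-fluorobenzyl group joins the other plain or halogenated benzyl groups in falling short of 3-azido-4-methoxybenzyl, with a 3.5-fold higher number from compound 1 to compound 4 (0.55 log units; beyond the scatter), and no compound shown goes against this. The 4-fluorobenzyl group and the plain benzyl group cannot be told apart, with a 1.1-fold lower number from compound 2 to compound 4 (0.03 log units; within the scatter). The step of an at least 1.5-fold lower number from compound 3 to compound 4 (0.19 log units; that floor lies within the scatter) settles no order. Compound 3 stands only at a limit: the limit of > 80000 nM in this assay, at which 1 of the 4 values shown sits.

On these data alone, whether the lower number of compound 1 goes with the azido group, the methoxy group or the two together remains open. Also open, as far as these compounds go, is how an amine, a carboxylic acid or a longer chain on the benzyl group would read in this assay.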